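A dimethoxyphenyl variant of a coumarin-triazole dienone

A few compounds are considered here, and "the series" means these few. Any claim that something is new, unique, unknown or untested is made for them only; others in the source may bear on it.

compound 1 `COc1ccccc1/C=C/C(=O)/C=C/c1ccc(OCc2cn(CCCOc3cc(=O)oc4ccccc34)nn2)c(OC)c1`: 57%
compound 2 `COc1cc(/C=C/C(=O)/C=C/c2ccccc2)ccc1OCc1cn(CCCCCOc2cc(=O)oc3ccccc23)nn1`: 22%
compound 3 `COc1cc(/C=C/C(=O)/C=C/c2ccco2)ccc1OCc1cn(CCCCOc2cc(=O)oc3ccccc23)nn1`: 43%

In a functional assay on COLO 205 cells (Homo sapiens) for inhibition, read by sulforhodamine B assay, with a stated time of 48 h, tested at 50 uM (a lower number here means less inhibition of growth, a higher number more inhibition of growth at the concentration tested), compound 1 gives 57%, the highest of the three numbers. Compound 3 gives 43%, and compound 2 gives 22%; both lie below compound 1 by more than the scatter. Compound 4 `COc1ccc(/C=C/C(=O)/C=C/c2ccc(OCc3cn(CCCOc4cc(=O)oc5ccccc45)nn3)c(OC)c2)cc1OC` differs from compound 1 in a single place: 3,4-dimethoxyphenyl in place of 2-methoxyphenyl on a double-bonded chain carbon bound to a double-bonded chain carbon. Within the data shown here, no pair of measured compounds isolates this change, since compounds 2 and 3 differ from compound 1 in more than one place, so the direction rests on a guess. In this assay the expected step is a number 7 percentage points lower from compound 1 to compound 4 (within the scatter), small and within the scatter. Compound 4 is therefore estimated at 50%, in a range from 30% to 70%.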

Compound 4, percent growth inhibition at one concentration: 65%
Estimate against measurement, compound 4: 15 percentage points below, and the stated range covers the measured number.
By their numbers in this assay, from the lowest: compound 2; then compound 3; then compounds 1 and 4 (each within the scatter of the next).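

In this assay, 3,4-dimethoxyphenyl in place of 2-methoxyphenyl gives a number 8 percentage points higher from compound 1 to compound 4 (within the scatter), the first step read at this position. The place on a double-bonded chain carbon bound to a double-bonded chain carbon thus accepts the larger group, with its added methoxy oxygen, without a change beyond the scatter. No measurement available explains this result. Still open, as far as these compounds go, is whether an amine or a carboxylic acid on this phenyl ring would keep the growth inhibition, and whether the step holds with a longer chain to the triazole.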